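A few compounds are considered here, and "the series" means these few. Any claim that something is new, unique, unknown or untested is made for them only; others in the source may bear on it.

Compound 1, `CCCC(=O)OCSc1ccccc1C(=O)NCCCCNC(C)=O`: 17.4 uM
Compound 2, `CCCC(=O)OCSc1ccccc1C(=O)Nc1ccccc1C(N)=O`: 50.1 uM

Of the compounds shown here, two have been measured in an ADME assay on CEM-SS cells (Homo sapiens) for cytotoxicity, read by XTT assay, with a stated time of 6 days; on this read-out lower numbers stand for higher toxicity in this test and higher numbers for lower toxicity in this test. Compound 1 gives 17.4 uM, the lowest of the two numbers; the nearest, compound 2, gives 50.1 uM, a gap that lies beyond the usual scatter. Within the data shown here, no single-point step between measured compounds is available, so the account rests on compound 1 alone.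

Compound 3, `C#CCNC(=O)CNC(=O)c1ccccc1SCOC(=O)CCC`, is not yet measured. It differs from compound 1 in one place: propargylcarbamoyl in place of 3-acetamidopropyl on a saturated chain carbon bound to an amide-type nitrogen. The rest of the structure, the shared core with its ester-bearing sulfur substituent, is unchanged.

Among the measured compounds shown here, with no measured pair to calibrate this change, only a modest step from compound 1 is expected, from compound 1 to compound 3 a 1.3-fold higher number from compound 1 to compound 3 (0.10 log units; within the scatter), a value not clearly beyond the scatter in either direction. For compound 3 the estimate in this assay is 22 uM, within a range of 8 uM to 60 uM.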

Compound 3, half-maximal toxic concentration: 95.4 uM
Compound 3: the middle estimate sits 4.3-fold (0.64 log units) below what was measured, and the stated range ends below it.
By their numbers in this assay, from the lowest: compound 1; then compounds 2 and 3 (each within the scatter of the next).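

In this assay, the saturated chain carbon bound to an amide-type nitrogen turns out to be a place where a change in the side chain can shift the read-out: propargylcarbamoyl in place of 3-acetamidopropyl gives a 5.5-fold higher number from compound 1 to compound 3 (0.74 log units; beyond the scatter), a move towards lower toxicity in this test. The step arises although the two groups have the same counts of hydrogen-bond donors and acceptors and neither carries a net charge, while a triple bond enters with the new group. Nothing available explains the size or direction of this step.

With only this one change at the position, the compounds shown cannot separate the contribution of the triple bond from that of the rest of the new group. They also leave open how an amine, a carboxylic acid or a longer chain would read at this place.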